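This account rests on a few compounds, and the source may have more. Where it says the series, first, only, none or still open, it means among the compounds named here.

Measured compounds:
- Compound 1, `CN(C)C(=O)CN1CCC(c2cc3c(-c4ccc(=O)n(C5CCC5)c4)ccnc3[nH]2)CC1`: in an ADME assay on microsomes from liver (Homo sapiens) for metabolic stability (on this read-out higher numbers stand for fast clearance and lower numbers for slow clearance), compound 1 gives < 3 uL/min; this is a limit of the assay, not a number.
- Compound 2, `CC(C)Cn1cc(-c2ccnc3[nH]c(C4CCN(CC(=O)N(C)C)CC4)cc23)ccc1=O`: in this assay compound 2 gives 21 uL/min.
- Compound 3, `CN(C)C(=O)CN1CCC(c2cc3c(-c4ccc(=O)n(CCC5CCOCC5)c4)ccnc3[nH]2)CC1`: in this assay compound 3 gives 19 uL/min.

Compound 3 holds the lowest of the two numbers, with compound 2 nearest: a 1.1-fold lower number from compound 2 to compound 3 (0.04 log units; within the scatter). Compound 1 stands apart at a limit (the limit of < 3 uL/min in this assay, at which 1 of the 3 values shown sits). The cyclobutyl compound differs from both chain-bearing compounds: an at least 7.0-fold higher number from compound 1 to compound 2 (0.84 log units; beyond the scatter) and an at least 6.3-fold higher number from compound 1 to compound 3 (0.80 log units; beyond the scatter).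

Compound 4, `CCn1cc(-c2ccnc3[nH]c(C4CCN(CC(=O)N(C)C)CC4)cc23)ccc1=O`, is not yet measured in this assay. Change from compound 3: hydrogen in place of oxan-4-yl on a saturated chain carbon, two bonds along the chain from an aromatic nitrogen. For the measured compounds named here, the only step that bears directly on a change of the chain at this position is the one from compound 2 to compound 3, which lay within the scatter; the steps from compound 1 show that a change on the aromatic nitrogen can move the number, but both involve cyclobutyl, not a shortened chain. Going by the values given here, no step shows a shortened chain on its own. The expected step is a 1.6-fold lower number from compound 3 to compound 4 (0.20 log units; within the scatter), small and uncertain in direction. Compound 4 is therefore estimated at 12 uL/min, range 4 uL/min to 30 uL/min.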

Compound 4, intrinsic clearance in a liver preparation (reported as CLH), per the amount of preparation that the assay uses: < 3 uL/min
Compound 4: no number, only a limit (the forecaster's own chance of this, stated with the estimate: 15%); middle value at least 4.0-fold (0.60 log units) from the limit.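

In this assay compound 4 gives < 3 uL/min, which is a limit of the assay and not a number. The chain on the aromatic nitrogen can therefore move the number: removing oxan-4-yl gives an at least 6.3-fold lower number from compound 3 to compound 4 (0.80 log units; beyond the scatter), and methyl in place of isopropyl gives an at least 7.0-fold lower number from compound 2 to compound 4 (0.84 log units; beyond the scatter), whereas the earlier exchange on this chain gave only a 1.1-fold lower number from compound 2 to compound 3 (0.04 log units; within the scatter). The step from compound 1 to compound 4 cannot be read, so cyclobutyl and ethyl cannot be ordered on this read-out: the limit of < 3 uL/min in this assay, at which 2 of the 4 values shown sit.

Still open, as far as these compounds go, is where between ethyl and isobutyl the number starts to rise, which a propyl group on the aromatic nitrogen would help to place. Also open, from the compounds shown here alone, is how a chain ending in an amine or a carboxylic acid in place of oxan-4-yl would read in this assay.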